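Fused dihydropyridine ketones: removing the nitro group of compound 2

The source may report more compounds than this note shows. Statements on the series, on what has been measured and on what is new or still open speak of the compounds shown alone.

The series is tested in an assay on isolated protein for inhibition of glucose-6-phosphatase catalytic subunit 1 (Homo sapiens), read by inositol phosphate accumulation, with a stated time of 30 min, tested at 100 uM; a higher number here means more inhibition at the concentration tested (going by the name of the read-out), a lower number less inhibition. For the measured compounds named here, compound 1, `O=C1CCCC2=C1C(c1ccc(F)cc1)C=C(c1ccccc1)N2`, is the only member with a number: in this assay compound 1 gives 21.9%. Compound 2, `CC1(C)CC(=O)C2=C(C1)NC(c1ccccc1)=CC2c1ccc([N+](=O)[O-])cc1`, is reported in this assay as "not active" (no number reported), without a number. Compound 3, `CCOC(=O)C1=CC(c2ccc(F)cc2)C2=C(CC(C)(C)CC2=O)N1`, is likewise reported in this assay as "not active" (no number reported), again with no number. Going by the values given here, compound 2 therefore stands among the two entries for which no value was given, and no step between measured compounds can be drawn from these data.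

Compound 4, `CC1(C)CC(=O)C2=C(C1)NC(c1ccccc1)=CC2c1ccccc1`, is the next member to be measured. It differs from compound 2 in one place: hydrogen in place of nitro on an aromatic carbon.

Among the compounds with values here, no measured pair shows what this change does in this assay. Within the data shown here, compound 2 is reported without a number, so the step cannot be sized from it; the only number, the low value of compound 1, suggests that inhibition across the set is modest. The expectation is for a change of no more than the usual scatter, if any, in the direction of weak inhibition. Compound 4 is expected to give about 10% in this assay, within a range from 0% to 28%, with a real chance that it is again reported without a number.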

Compound 4, a percentage reported as inhibition, at one concentration (the size of the read-out at that concentration, not a potency): "not active" (no number reported)
No number was reported for compound 4; no gap can be computed for the estimate.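

Compound 2 and compound 4 are both reported as not active, without a number, in this assay, so no step can be read for the change from 4-nitrophenyl to phenyl. Nothing measured here bears on this result. The compounds shown leave open what any single change does to inhibition, with only compound 1 at 21.9% carrying a number.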